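A Methyl Step in an Amide Series That Shows Only Limits

A few compounds are considered here, and "the series" means these few. Any claim that something is new, unique, unknown or untested is made for them only; others in the source may bear on it.

Compound 1 `Cc1ccc(NC(=O)c2cccc(C(F)(F)F)c2)cc1OC1CCN(C(=O)c2cccnc2)CC1` gives a limit in an ADME assay on BaF3 cells (Mus musculus) for antiproliferative activity (on this read-out lower numbers stand for stronger inhibition of growth and higher numbers for weaker inhibition of growth), > 10000 nM. Compound 2 `Cc1ccc(NC(=O)c2cccc(C(F)(F)F)c2)cc1OC1CCN(C(=O)c2ccncc2)CC1` likewise gives only a limit in this assay, > 10000 nM. Compound 3 `O=C(Nc1cccc(OC2CCN(C(=O)c3cccnc3)CC2)c1)c1cccc(C(F)(F)F)c1` also gives only a limit in this assay, > 10000 nM.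

All three measured values in this assay sit at the same limit, which is what the limit of > 10000 nM in this assay, at which 3 of the 3 values shown sit, records, and because of the limit of > 10000 nM in this assay, at which 3 of the 3 values shown sit, neither measured step can be read: a step that the two limits leave unreadable from compound 3 to compound 1, the change being (methyl in place of hydrogen on an aromatic carbon), and a step that the two limits leave unreadable from compound 1 to compound 2. The difference between the core of compound 2 and the core of compound 3 is not broken down here.

Compound 4 `Cc1ccc(NC(=O)c2ccc(C)c(C(F)(F)F)c2)cc1OC1CCN(C(=O)c2ccncc2)CC1` is not yet measured. It differs from compound 2 by methyl in place of hydrogen on an aromatic carbon. This is the same kind of change as that from compound 3 to compound 1, but the place differs: in compound 4 the methyl enters ortho to a trifluoromethyl group (4 heavy atoms), whereas in compound 1 it entered ortho to a large group. Since compound 2 gives only a limit, > 10000 nM, and the earlier step is unreadable, the expected step is a step that the limit leaves unreadable from compound 2 to compound 4, most likely again a limit. Compound 4 is therefore expected to give 15000 nM, estimated between 5000 nM and 50000 nM.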

Compound 4, concentration for 50% growth inhibition: 6390 nM
Compound 4: the middle estimate sits 2.3-fold (0.37 log units) above what was measured; measured number inside the range.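

In this assay, methyl in place of hydrogen, ortho to a trifluoromethyl group and para to a large group, gives an at least 1.5-fold lower number from compound 2 to compound 4 (0.19 log units; that floor lies within the scatter). On these data alone, this step starts from a limit, so its true size stays unknown, and its printed floor alone does not separate compound 4 from compound 2 beyond the usual scatter. It does not show that the methyl change carries from one core to another, since the same kind of change from compound 3 to compound 1 stands at another place, and neither that step nor the step from compound 1 to compound 2 can be read because of one shared limit: the limit of > 10000 nM in this assay, at which 3 of the 4 values shown sit.

The compounds shown leave open whether this same methyl, placed on the 3-(trifluoromethyl)phenyl ring of compound 1, would also bring a number within the range of the assay. They also leave open whether a chlorine atom or a methoxy group at that place would give a result like that of the methyl in compound 4.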